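A methyl group leaves compound 3

The source may report more compounds than this note shows. Statements on the series, on what has been measured and on what is new or still open speak of the compounds shown alone.

In a functional assay on Jurkat cells (Homo sapiens) for cytotoxicity, with a stated time of 48 h (a lower number here means a stronger inhibitor, a higher number a weaker inhibitor), three compounds on a shared core have been measured. Compound 1 `CCOC(=O)CC1C(C(=O)OCC)=C(N)Oc2ccc(Br)cc21` carries bromo and gives 57300 nM as its value. Compound 2 `CCOC(=O)CC1C(C(=O)OCC)=C(N)Oc2ccc(-c3ccc(C(C)(C)C)cc3)cc21` carries 4-(tert-butyl)phenyl and gives 35500 nM as its value, and this exchange amounts to a 1.6-fold lower number from compound 1 to compound 2 (0.21 log units; within the scatter) only. Compound 3 `CCOC(=O)CC1C(C(=O)OCC)=C(N)Oc2ccc(-c3cc(O)cc(OC)c3)cc21` carries 3-hydroxy-5-methoxyphenyl and gives 4200 nM as the lowest of the three values. Its group produces a 14-fold lower number from compound 1 to compound 3 (1.13 log units; beyond the scatter) when it replaces bromo and an 8.5-fold lower number from compound 2 to compound 3 (0.93 log units; beyond the scatter) when it replaces 4-(tert-butyl)phenyl.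

Within the data shown here, compound 4 `CCOC(=O)CC1C(C(=O)OCC)=C(N)Oc2ccc(-c3cc(O)cc(O)c3)cc21` bears 3,5-dihydroxyphenyl instead, with hydrogen in place of methyl on an oxygen on an aromatic ring as the only change. Among the measured compounds shown here, no measured step removes such a methyl, since those steps exchanged whole groups on an aromatic carbon. For the measured compounds named here, they show only that this group can move the number, and they give no direct guide to a change this small. An estimated 1.1-fold lower number from compound 3 to compound 4 (0.04 log units; within the scatter) is therefore expected, with no firm direction. Compound 4 is estimated at 3800 nM with an expected range from 1500 nM to 10000 nM for its measurement.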

Compound 4, half-maximal inhibitory concentration: 18300 nM
For compound 4 the middle estimate is 4.8-fold (0.68 log units) below the measured one; the measured number lies above the stated range.
By their numbers in this assay, from the lowest: compound 3; then compounds 4, 2 and 1 (each within the scatter of the next, the first and the last beyond it).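

In this assay, the methyl on the oxygen of compound 3 turns out to count: its loss gives a 4.4-fold higher number from compound 3 to compound 4 (0.64 log units; beyond the scatter) as the result of a change of one heavy atom, a sensitivity that the exchanges of whole groups could not show. With hydroxy in place of methoxy, the group no longer stands clear of 4-(tert-butyl)phenyl (a 1.9-fold lower number from compound 2 to compound 4 (0.29 log units; within the scatter)), and its margin over bromo narrows (a 3.1-fold lower number from compound 1 to compound 4 (0.50 log units; beyond the scatter)). Nothing available explains why this methyl matters.

The compounds shown leave open whether a longer chain on this oxygen, such as ethoxy, would keep or extend the lower number of compound 3. They also do not tell whether an amine in place of the remaining hydroxy would be tolerated.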